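The source may hold more compounds than are shown below. What is called first, only, known or untested is meant among the compounds shown, and "the series" means these compounds.

Three compounds have been measured in an assay on HeLa cells for displacement of a labelled ligand from 5-hydroxytryptamine receptor 6 (Homo sapiens); on this read-out lower numbers stand for stronger inhibition and higher numbers for weaker inhibition:
compound 1, `CSc1nc2ccccn2c(=N)c1S(=O)(=O)c1ccc(F)cc1`, 22 nM;
compound 2, `CSc1nc2ccccn2c(=O)c1S(=O)(=O)c1ccccc1`, 52 nM;
compound 3, `CSc1nc2ccc(F)cn2c(=N)c1S(=O)(=O)c1ccccc1`, 28 nM.

Compound 3 stands with the second highest of the three numbers, but its gap to compound 1 and its gap to compound 2 both lie within the usual scatter, so the three read as one cluster. Compound 4, `CSc1nc2ccc(C(N)=O)cn2c(=N)c1S(=O)(=O)c1ccccc1`, is not yet measured. Relative to compound 3 it carries carbamoyl in place of fluoro on an aromatic carbon. For the measured compounds named here, no measured pair shows the effect of such a change, so the direction can only be guessed; a modest weakening, from compound 3 to compound 4, is expected, a 2.1-fold higher number from compound 3 to compound 4 (0.33 log units; beyond the scatter), though a step within the scatter is also plausible. Compound 4 is therefore estimated at 60 nM, within 15 nM to 250 nM.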

Compound 4, half-maximal inhibitory concentration: 8.8 nM
Estimate against measurement, compound 4: 6.8-fold (0.83 log units) above; the measured number lies below the stated range.
By their numbers in this assay, from the lowest: compound 4; then compounds 1, 3 and 2 (each within the scatter of the next, the first and the last beyond it).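

In this assay, for the compounds shown here, carbamoyl in place of fluoro on this aromatic carbon gives a 3.2-fold lower number from compound 3 to compound 4 (0.50 log units; beyond the scatter) and is the first step measured at this position. The position therefore accepts a group of more heavy atoms than fluoro, one that brings a hydrogen-bond donor and acceptor, without any loss of binding. Nothing shown here accounts for the step.

From the compounds shown here alone, whether the gain depends on the carbonyl or on the amide hydrogen remains open. So does whether a nitrile, a carboxylic acid or an amine on this carbon would give a similar result.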